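The source may hold more compounds than are shown below. What is called first, only, known or untested is meant among the compounds shown, and "the series" means these compounds.

Series notes, this assay.

Measured so far:
- compound 1, `CCCCSc1nnc(COc2cc(C)c3c(C)cc(=O)oc3c2)o1`: in a functional assay on MCF7 cells (Homo sapiens) for antiproliferative activity, read by MTT assay, with a stated time of 24 h (a lower number here means a stronger inhibitor, a higher number a weaker inhibitor), compound 1 gives > 100000 nM, a limit of the assay.
- compound 2, `Cc1cc(OCc2nnc(SCc3ccccc3)o2)cc2oc(=O)cc(C)c12`: compound 2 gives > 100000 nM, again a limit of the assay.
- compound 3, `CCCCCCS(=O)(=O)c1nnc(COc2cc(C)c3c(C)cc(=O)oc3c2)o1`: compound 3 gives > 100000 nM, also a limit of the assay.

Compound 3 therefore stands where every value in the set stands: all three sit at the limit of > 100000 nM in this assay, at which 3 of the 3 values shown sit, and no number is known for any of them. The steps among them, a step that the two limits leave unreadable from compound 1 to compound 2, a step that the two limits leave unreadable from compound 1 to compound 3 and a step that the two limits leave unreadable from compound 2 to compound 3, cannot be sized for that reason.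

Compound 4, `Cc1cc(OCc2nnc(S(=O)(=O)Cc3ccc(F)c(F)c3)o2)cc2oc(=O)cc(C)c12`, is not yet measured. It differs from compound 3 by 3,4-difluorophenyl in place of pentyl on a saturated chain carbon bound to a sulfonyl sulfur. Among the measured compounds shown here, the steps that bear on this change are those from compound 1 to compound 2 and from compound 2 to compound 3, which alter the same place and the same sulfur substituent, and both are unreadable. For the measured compounds named here, no measured step gives a direction or a size. The expected step that the limit leaves unreadable from compound 3 to compound 4 is thus set at no change beyond the scatter, with the outcome most likely another limit. Compound 4 is estimated at 150000 nM, range 30000 nM to 600000 nM.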

Compound 4, half-maximal inhibitory concentration: 55200 nM
Compound 4: middle estimate off by 2.7-fold (0.43 log units), on the high side; measured number inside the range.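

In this assay, compound 4 is the only compound shown that gives a number rather than a limit of the assay: the limit of > 100000 nM in this assay, at which 3 of the 4 values shown sit.
Among the compounds shown here, on the saturated chain carbon bound to a sulfonyl sulfur, 3,4-difluorophenyl in place of pentyl gives an at least 1.8-fold lower number from compound 3 to compound 4 (0.25 log units; that floor lies within the scatter), the first step that can be read at all. Only a floor is known for this step, so its true size remains unread, and the change is not shown to lie beyond the scatter.

Whether the fluorines or the aromatic ring itself account for the step stays open, as no pair shown separates the two. As far as these compounds go, how a chain ending in an amine or a carboxylic acid at this place would read in this assay is also open.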